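Sulfonamide series: aryl replacement at the carbamoyl position

The source may report more compounds than this note shows. Statements on the series, on what has been measured and on what is new or still open speak of the compounds shown alone.

Measured compounds in an assay on isolated protein for inhibition of alkaline phosphatase, tissue-nonspecific isozyme (Homo sapiens); a higher number here means a weaker inhibitor, a lower number a stronger inhibitor:
compound 1 `COc1ccc(Cl)cc1S(=O)(=O)Nc1cncc(-c2ccncc2)c1`, 73 nM
compound 2 `COc1ccc(Cl)cc1S(=O)(=O)Nc1cncc(-c2ccccc2C)c1`, 178 nM
compound 3 `CCNC(=O)c1cncc(NS(=O)(=O)c2cc(Cl)ccc2OC)c1`, 193 nM

Compound 3 gives the highest number of the three. The step of a 1.1-fold higher number from compound 2 to compound 3 (0.04 log units; within the scatter) lies within the scatter, while the step of a 2.6-fold higher number from compound 1 to compound 3 (0.42 log units; beyond the scatter) is beyond it; so compound 3 and compound 2 are indistinguishable here, and only compound 1 stands apart with the lower number.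

Compound 4 `COc1ccc(Cl)cc1S(=O)(=O)Nc1cncc(-c2ccc(C)cc2)c1` is not yet measured. It differs from compound 3 by 4-methylphenyl in place of ethylcarbamoyl on an aromatic carbon.

Among the compounds with values here, two measured steps bear on this change. Going from an aromatic substituent to ethylcarbamoyl cost a 2.6-fold higher number from compound 1 to compound 3 (0.42 log units; beyond the scatter) when the aromatic ring was pyridin-4-yl, but nothing beyond the scatter when it was 2-methylphenyl, a 1.1-fold higher number from compound 2 to compound 3 (0.04 log units; within the scatter). The group entering in compound 4 is a methylphenyl like that of compound 2, differing only in where the methyl sits, so the reverse of the step from compound 2 to compound 3 is the closer guide: a step within the scatter, possibly a slight move toward a lower number.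

Compound 4 is therefore expected to give about 150 nM in this assay, in the range 60 nM to 350 nM, an expected step of a 1.3-fold lower number from compound 3 to compound 4 (0.11 log units; within the scatter).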

Compound 4, half-maximal inhibitory concentration: 147 nM
Compound 4: middle estimate off by 1.0-fold (0.01 log units), on the high side, within the range that was stated.
By their numbers in this assay, from the lowest: compounds 1, 4, 2 and 3 (each within the scatter of the next, the first and the last beyond it).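

In this assay, 4-methylphenyl and 2-methylphenyl cannot be told apart (a 1.2-fold lower number from compound 2 to compound 4 (0.08 log units; within the scatter)), and neither can 4-methylphenyl and ethylcarbamoyl (a 1.3-fold lower number from compound 3 to compound 4 (0.12 log units; within the scatter)), so neither moving the methyl nor exchanging the carbon-only aromatic ring for a chain with a hydrogen-bond donor and acceptor gives a step beyond the scatter. Compound 1 stands apart from compound 2 and compound 3, but this separation does not extend to the new methylphenyl (a 2.0-fold higher number from compound 1 to compound 4 (0.30 log units; within the scatter)), which stays within the scatter. No available evidence bears on this result.

Going by these compounds, how an unsubstituted phenyl would compare with pyridin-4-yl at this position remains open. Also open, on these data alone, is how an amine, a carboxylic acid or a longer chain would read out here.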